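The source may hold more compounds than are shown below. What is called first, only, known or untested is meant among the compounds shown, and "the series" means these compounds.

Compound 2 `Cc1c(C(=O)Nc2cc(F)c(F)c(Cl)c2)sc(N)c1C#N` has no result in an ADME assay on HepG2 cells (Homo sapiens) for cytotoxicity, read by XTT assay, with a stated time of 2 days; on this read-out higher numbers stand for lower toxicity in this test and lower numbers for higher toxicity in this test: for compound 2 the record reads "not determined" (no result reported). The nearest reference is compound 1 `Cc1c(C(=O)Nc2ccc(F)c(F)c2)sc(N)c1C#N`, which in this assay gives > 100000 nM, a limit of the assay rather than a number, as the limit of > 100000 nM in this assay, at which 1 of the 2 values shown sits, shows. Compound 3 `Cc1c(C(=O)Nc2cc(F)c(F)c(Cl)c2)sc(N)c1C(N)=O` differs from compound 2 by carbamoyl in place of cyano on an aromatic carbon. For the measured compounds named here, with no measured pair of this kind available, no step beyond the usual scatter is expected in this assay on going from compound 2 to compound 3. Compound 3 is therefore estimated at 100000 nM, within the range 30000 nM to 300000 nM, most probably reported once more as a limit.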

Compound 3, half-maximal cytotoxic concentration: 72000 nM
The estimate for compound 3 lay 1.4-fold (0.14 log units) above the measured number; the range from low to high includes it.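

For the compounds shown here, with no number for compound 2, no step to compound 3 can be read in this assay. The compounds shown leave open what carbamoyl in place of cyano on an aromatic carbon changes in this assay.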